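The source may report more compounds than this note shows. Statements on the series, on what has been measured and on what is new or still open speak of the compounds shown alone.

Three compounds of this set share one core, the carbamate-linked aryl ester seen in compound 1 `CC(C)c1cccc(C(C)C)c1OC(=O)NC(=O)OC(c1ccccc1)c1ccccc1`, compound 2 `CC(C)c1cccc(C(C)C)c1OC(=O)NC(=O)OCc1ccccc1` and compound 3 `CCCCCCCCCCCOC(=O)NC(=O)Oc1c(C(C)C)cccc1C(C)C`. In an assay on microsomes from intestine for inhibition of acyl-CoA:cholesterol acyltransferase (Oryctolagus cuniculus) (a higher number here means a weaker inhibitor, a lower number a stronger inhibitor), compound 1 gives 350 nM, compound 2 gives 77 nM and compound 3 gives 140 nM. Compound 2 thus holds the lowest of the three numbers; the gap to compound 3 lies within the scatter, the gap to compound 1 beyond it, as the step of a 4.5-fold lower number from compound 1 to compound 2 (0.66 log units; beyond the scatter) shows.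

Compound 4 `CCCCC(C)(C)OC(=O)NC(=O)Oc1c(C(C)C)cccc1C(C)C` has not yet been measured in this assay. It differs from compound 2 in one place: 1,1-dimethylpentyl in place of benzyl on an oxygen next to a carbonyl group. The step that bears most directly on this change is a 1.8-fold higher number from compound 2 to compound 3 (0.26 log units; within the scatter), where an aromatic group on the same oxygen gave way to a chain with no change beyond the scatter. On that basis no step beyond the scatter is expected here, with a slight drift toward a higher number allowed for; the expected step is a 1.6-fold higher number from compound 2 to compound 4 (0.19 log units; within the scatter).

Compound 4 is therefore estimated at 120 nM, with a range from 45 nM to 320 nM.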

Compound 4, half-maximal inhibitory concentration: 64 nM
Compound 4: the middle estimate sits 1.9-fold (0.27 log units) above what was measured; the range from low to high includes it.
By their numbers in this assay, from the lowest: compounds 4, 2 and 3 (each within the scatter of the next, the first and the last beyond it); then compound 1.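

Replacing benzyl with 1,1-dimethylpentyl on the oxygen next to a carbonyl group gives a 1.2-fold lower number from compound 2 to compound 4 (0.08 log units; within the scatter) in this assay and leaves the heavy-atom count unchanged, which the earlier change to the longer chain of compound 3 did not do. An aromatic ring is therefore not needed on this oxygen for a value level with that of compound 2, and a branched chain without any ring serves here as well. No measured property is available to explain why the two groups read alike.

From the compounds shown here alone, it remains open whether a cyclohexylmethyl group, a saturated ring of similar size, would read the same way. Also open, going by these compounds, is how far this oxygen accepts a longer branched chain, or a chain ending in an amine or a carboxylic acid.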